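Furan-2-yl in place of 4-chlorophenyl on the enone chain

The compounds below may be only part of what the source reports. "The series", "measured", "known", "first", "only" and "open" are said of these compounds alone.

Of the compounds shown here, two have been tested in a functional assay on the whole organism (strain albino) for inhibition, with Rattus norvegicus as the target, read by paw edema, with stated times of 30 min and 2 h, at a dose of 100 mg/kg by the oral route; a higher number here means more inhibition at the dose given (going by the name of the read-out), a lower number less inhibition. Compound 1 `O=C(CO[N+](=O)[O-])Nc1ccc(C(=O)/C=C/c2ccco2)cc1` carries a furan-2-yl group on the chain and a nitrooxy-acetamide on the anilide; in this assay compound 1 gives 36%. Compound 2 `CC(Br)C(=O)Nc1ccc(C(=O)/C=C/c2ccc(Cl)cc2)cc1` carries a 4-chlorophenyl group on the chain and a 2-bromopropanamide on the anilide; in this assay compound 2 gives 45%. The two numbers lie within the usual scatter of each other, so compound 2 stands beside compound 1 rather than apart from it.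

Compound 3 `CC(Br)C(=O)Nc1ccc(C(=O)/C=C/c2ccco2)cc1` has not yet been measured. It differs from compound 2 in one place: furan-2-yl in place of 4-chlorophenyl on a double-bonded chain carbon bound to a double-bonded chain carbon. Among the measured compounds shown here, compound 1 already shows the furan-2-yl group, though with a different anilide, and no step between measured compounds isolates this change. The two known values give no reason to expect a move beyond the scatter; the step from compound 2 to compound 3 is estimated at a number 5 percentage points lower from compound 2 to compound 3 (within the scatter) in this assay. Compound 3 is therefore expected to give about 40% in this assay, within a range from 28% to 52%.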

Compound 3, a percentage reported as inhibition, in the whole organism at one dose (the size of the read-out at that dose, not a potency): 37%
Compound 3: middle estimate off by 3 percentage points, on the high side, within the range that was stated.
By their numbers in this assay, from the lowest: compounds 1, 3 and 2 (each within the scatter of the next).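

In this assay, the exchange of 4-chlorophenyl for furan-2-yl on a double-bonded chain carbon bound to a double-bonded chain carbon can now be read on its own, as a number 8 percentage points lower from compound 2 to compound 3 (within the scatter) and so within the scatter, which means this read-out does not separate the two rings at this place with the 2-bromopropanamide in the anilide. Compound 3 also isolates a second place with the furan-2-yl group held constant: 1-bromoethyl in place of (nitrooxy)methyl on a carbonyl carbon gives a number 1 percentage points higher from compound 1 to compound 3 (within the scatter) and this step too stays within the scatter, so neither single change separates the compounds it links. Nothing measured here offers an explanation for these two results.

The compounds shown leave open whether either place can move the number beyond the scatter, for instance with a dimethylamino group in place of 1-bromoethyl on the carbonyl carbon or a pyridin-3-yl group in place of furan-2-yl on the chain. They also leave open how the 4-chlorophenyl group behaves alongside the (nitrooxy)methyl group, so it cannot yet be said whether the two changes act independently.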